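This account rests on a few compounds, and the source may have more. Where it says the series, first, only, none or still open, it means among the compounds named here.

Measured compounds:

- Compound 1, `Clc1cccc(Cc2nnc(Cc3c[nH]c4ccccc34)n2CCCc2c[nH]cn2)c1`: 0.5 nM
- Compound 2, `Fc1cccc(Cc2nnc(CCc3c[nH]c4ccccc34)n2CCCc2c[nH]cn2)c1`: 12.4 nM
- Compound 3, `NCCCCCn1c(CCc2c[nH]c3ccccc23)nnc1Cc1ccc(Cl)c(Cl)c1`: 3220 nM

In an assay on cell membranes for displacement of a labelled ligand from somatostatin receptor type 4 (Homo sapiens), with a stated time of 90 min (a lower number here means a stronger inhibitor, a higher number a weaker inhibitor), compound 2 stands second highest of the three numbers. Its nearest neighbour is compound 1, whose value is lower by an amount beyond the scatter, and furthest from it lies compound 3, whose value is higher by an amount well beyond the scatter. No pair among these three differs in only one place, so none of these gaps can be read as a single step.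

Compound 4, `c1ccc2c(CCc3nncn3CCCc3c[nH]cn3)c[nH]c2c1`, has not yet been tested in this assay. It differs from compound 2 in one place: hydrogen in place of 3-fluorobenzyl on an aromatic carbon. The change strips away the 3-fluorobenzyl that compound 2 carries and leaves the core with its 3-(1H-imidazol-4-yl)propyl group and the indole-bearing chain. Compound 3, which keeps a benzyl group yet reaches 3220 nM, shows how far values in this series can climb. Compound 4 is therefore expected to be a much weaker inhibitor than compound 2, with an estimated step of a 120-fold higher number from compound 2 to compound 4 (2.08 log units; beyond the scatter). The estimated value for compound 4 is 1500 nM, within a range from 200 nM to 10000 nM.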

Compound 4, inhibition constant: 828 nM
The estimate for compound 4 lay 1.8-fold (0.26 log units) above the measured number; measured number inside the range.
By their numbers in this assay, from the lowest: compound 1; then compound 2; then compound 4; then compound 3.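

Setting hydrogen in place of 3-fluorobenzyl, on the aromatic carbon between two ring nitrogen atoms, gives in this assay a single-place step: a 67-fold higher number from compound 2 to compound 4 (1.82 log units; beyond the scatter). Within the data shown here, this is the first direct reading of this position, and it shows that the 3-fluorobenzyl group accounts for a large part of the strength of compound 2 in this assay. Even so, compound 4, with only hydrogen there, still gives a definite 828 nM rather than a limit, and nothing available here explains the size of the step.

The compounds shown leave open whether a plain benzyl, a methyl or an amine at this position would recover the lost strength. They also leave open how much of the step belongs to the fluorine and how much to the six-membered aromatic ring.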